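Nitro for Trifluoromethyl: Cytotoxicity in a Diaryl Ether Series

The compounds below may be only part of what the source reports. "The series", "measured", "known", "first", "only" and "open" are said of these compounds alone.

Measured compounds:
- compound 1, `Clc1ccc(OC(CCn2ccnc2)c2ccccc2)c(Cl)c1`: 56500 nM
- compound 2, `FC(F)(F)c1ccc(OC(CCn2ccnc2)c2ccccc2)cc1`: 86000 nM
- compound 3, `Clc1ccc(C(CCn2ccnc2)Oc2ccc(Cl)cc2Cl)cc1`: 61000 nM

In a functional assay on U-937 cells (Homo sapiens) for cytotoxicity (on this read-out higher numbers stand for lower toxicity in this test and lower numbers for higher toxicity in this test), compound 2 gives the highest of the three numbers, but its nearest neighbour is compound 3 with 61000 nM and its furthest is compound 1 with 56500 nM, and both gaps are within the scatter. So no compound can be called less or more toxic than another here; all three sit at a similar level.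

The unmeasured compound 4, `O=[N+]([O-])c1ccc(OC(CCn2ccnc2)c2ccccc2)cc1`, differs from compound 2 by a single change: nitro in place of trifluoromethyl on an aromatic carbon.

For the measured compounds named here, the only measured step, a 1.1-fold higher number from compound 1 to compound 3 (0.03 log units; within the scatter), is a different kind of change at a different place, so it bears on the present step only in showing that a change on an aromatic carbon of this core left this assay essentially unchanged. Going by the values given here, no measured step exchanges one substituent for another on the aryl ether ring. On that basis compound 4 is expected to stay near compound 2, with a 1.2-fold lower number from compound 2 to compound 4 (0.09 log units; within the scatter) as the estimated step and no movement beyond the scatter. Compound 4 is therefore estimated at 70000 nM, within 30000 nM to 160000 nM.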

Compound 4, half-maximal cytotoxic concentration: 97200 nM
Compound 4: the middle estimate sits 1.4-fold (0.14 log units) below what was measured; the range from low to high includes it.
By their numbers in this assay, from the lowest: compounds 1, 3, 2 and 4 (each within the scatter of the next).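

In this assay the exchange of trifluoromethyl for nitro on an aromatic carbon, para to a large group, gives a 1.1-fold higher number from compound 2 to compound 4 (0.05 log units; within the scatter). The earlier compounds shown here offered only the gain of a chloro at another place, whereas this is a direct exchange of one substituent for another at this position, and the read-out stays at a similar level. The result also shows that a group counted with hydrogen-bond acceptors can replace one counted with none, with no change beyond the scatter, although nothing among the data given accounts for this.

Going by these compounds, whether an amine, a carboxylic acid or a longer alkyl chain at this place would also stay at this level remains open. So does whether nitro in place of trifluoromethyl would behave alike on the core of compound 3.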